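The compounds below may be only part of what the source reports. "The series", "measured", "known", "first", "only" and "open" are said of these compounds alone.

Measured so far in a functional assay on GLC82 cells (Homo sapiens) for cytotoxicity, read by MTT assay, with a stated time of 72 h; on this read-out lower numbers stand for stronger inhibition and higher numbers for weaker inhibition:
compound 1, `Cc1ccc(C(=O)NC(=S)NNc2ncnc3ccccc23)cc1`, gives 11200 nM
compound 2, `O=C(NC(=S)NNc1ncnc2ccccc12)c1cccc(Cl)c1`, gives 3240 nM
compound 3, `COc1cc2ncnc(NNC(=S)NC(=O)c3cccc(Cl)c3)c2cc1OC`, gives 8370 nM

Among these three numbers compound 3 stands second highest. Its nearest neighbour is compound 1, whose number lies within the usual scatter of it, so the two cannot be told apart. Compound 2 gives the lowest number of the three, clearly below compound 3.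

The next compound, compound 4, `COc1cc2ncnc(NNC(=S)NC(=O)c3ccccc3F)c2cc1OC`, shares the core of compound 3 and differs from it in one place: 2-fluorophenyl in place of 3-chlorophenyl on a carbonyl carbon. Going by the values given here, only one measured step concerns a change on that same carbonyl carbon: a 3.5-fold lower number from compound 1 to compound 2 (0.54 log units; beyond the scatter). That step swapped a different pair of groups, so it shows merely that changing the ring on the carbonyl carbon can shift the number modestly, without saying in which direction a switch away from 3-chlorophenyl would go. On this thin basis, compound 4 is expected to stay near compound 3, with a small rise in the number counted as the more likely side; the expected step is a 1.4-fold higher number from compound 3 to compound 4 (0.16 log units; within the scatter). Compound 4 is therefore estimated at 12000 nM, within a range from 4500 nM to 32000 nM.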

Compound 4, half-maximal inhibitory concentration: 8640 nM
Compound 4: the middle estimate sits 1.4-fold (0.14 log units) above what was measured, within the range that was stated.
By their numbers in this assay, from the lowest: compound 2; then compounds 3, 4 and 1 (each within the scatter of the next).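

In this assay, putting 2-fluorophenyl in place of 3-chlorophenyl on this carbonyl carbon gives a 1.0-fold higher number from compound 3 to compound 4 (0.01 log units; within the scatter), so on the core of compound 3 these two groups cannot be told apart. Going by these compounds alone, the earlier compounds showed only that a change at this place can matter: a 3.5-fold lower number from compound 1 to compound 2 (0.54 log units; beyond the scatter), but on a different core and with a different pair of groups. This new step adds that not every change of ring here separates two compounds, at least for this pair, which have the same count of heavy atoms and differ in which halogen they carry and where its name places it; no measurement at hand explains why the two match.

From the compounds shown here alone, both groups are phenyl rings carrying a single halogen, so it stays open whether the same holds for a ring carrying an amine or a carboxylic acid, or for a longer alkyl chain in place of the ring on this carbonyl carbon. Going by these compounds, it also stays open whether 2-fluorophenyl would match 3-chlorophenyl on the core of compound 2.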